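Swapping Trifluoromethyl for Ethyl on a Low-Toxicity Chain

The source may hold more compounds than are shown below. What is called first, only, known or untested is meant among the compounds shown, and "the series" means these compounds.

Compound 1 `O=C1N(CCC(CCOc2ccc(-c3ccc(Cl)cc3)cc2)C(F)(F)F)CCN1c1ccncc1` has been tested in an ADME assay on cells (Homo sapiens) for cytotoxicity; on this read-out higher numbers stand for lower toxicity in this test and lower numbers for higher toxicity in this test. For compound 1 the read-out is a limit rather than a number, > 12500 nM, which corresponds to the limit of > 12500 nM in this assay, at which 1 of the 2 values shown sits. A second member of the same series, compound 2 `Cc1nc(-c2ccc(OCCC(C)CCN3CCN(c4ccncc4)C3=O)cc2)no1`, was measured in the same way. For compound 2 the read-out is also a limit, > 6250 nM, corresponding to the limit of > 6250 nM in this assay, at which 1 of the 2 values shown sits. Among the measured compounds shown here, both results lie beyond what the test resolves, so no step between the two compounds can be sized, and compound 1 cannot be ranked against compound 2.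

Compound 3 `CCC(CCOc1ccc(-c2ccc(Cl)cc2)cc1)CCN1CCN(c2ccncc2)C1=O` has not yet been measured. It differs from compound 1 by ethyl in place of trifluoromethyl on a saturated chain carbon bound to two saturated chain carbons. For the measured compounds named here, with no measured step available, the expected step of a number no higher from compound 1 to compound 3 (the limit leaves the size open) is none beyond the usual scatter. Compound 3 is therefore estimated at 12500 nM in this assay, with a range from 5000 nM to 30000 nM, and the result is expected most likely to be reported again as a limit.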

Compound 3, half-maximal cytotoxic concentration: > 25000 nM
Compound 3 ended at the assay's limit; the forecaster's own chance of this, stated with the estimate: 70%; middle value at least 2.0-fold (0.30 log units) away from the limit.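

Compound 1 and compound 3 are both reported only as limits in this assay, so the step between them, ethyl in place of trifluoromethyl, cannot be read. The compounds shown leave open where the true half-maximal cytotoxic concentration of each lies, and whether this swap changes it at all.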